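Amide swap and acetamido on the aryl ring

The compounds below may be only part of what the source reports. "The series", "measured", "known", "first", "only" and "open" are said of these compounds alone.

Measured in a functional assay on Huh-5-2 cells (Homo sapiens), read by MTT assay; a lower number here means that less compound is tolerated, a higher number that more compound is tolerated:
- compound 1 `CCCNC(=O)c1ccc(-c2ccc(Cl)cc2)c(COc2ccc(-c3nc4cc(C(=O)O)ccc4n3C3CCCCC3)c(F)c2)c1`: 24000 nM
- compound 2 `O=C(O)c1ccc2c(c1)nc(-c1ccc(OCc3cc(C(=O)N4CCC(O)CC4)ccc3-c3ccc(Cl)cc3)cc1F)n2C1CCCCC1`: 26000 nM

Only these two numbers are available so far, and compound 2 at 26000 nM stands within the scatter of compound 1.

Next comes compound 3 `CC(=O)Nc1ccc(-c2ccc(Cl)cc2)c(COc2ccc(-c3nc4cc(C(=O)O)ccc4n3C3CCCCC3)c(F)c2)c1`, with acetamido in place of (4-hydroxypiperidin-1-yl)carbonyl on an aromatic carbon. This place is para to a 4-chlorophenyl group.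

Among the measured compounds shown here, the one measured step that bears on this is a 1.1-fold higher number from compound 1 to compound 2 (0.03 log units; within the scatter), with 4-hydroxypiperidin-1-yl in place of propylamino on a carbonyl carbon. That step exchanged only the group on the carbonyl carbon. For the measured compounds named here, no measured step replaces the whole (4-hydroxypiperidin-1-yl)carbonyl group, so the support is indirect and the range stays wide.

No shift beyond the scatter is expected in this assay, and no direction can be argued with confidence. The expected change is a 1.1-fold lower number from compound 2 to compound 3 (0.03 log units; within the scatter). For compound 3 the estimate is 24000 nM, with an expected range of 11000 nM to 50000 nM.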

Compound 3, half-maximal cytotoxic concentration: 24000 nM
Compound 3: middle estimate and measured number agree at the digits printed, and the stated range covers the measured number.
By their numbers in this assay, from the lowest: compounds 1, 3 and 2 (each within the scatter of the next).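

Notes on this position: in this assay, the earlier step changed only the group on the carbonyl carbon, whereas here the whole (4-hydroxypiperidin-1-yl)carbonyl group gives way to acetamido, and the result is a 1.1-fold lower number from compound 2 to compound 3 (0.03 log units; within the scatter). The comparison with the propyl amide gives no change at the digits printed from compound 1 to compound 3 (within the scatter), so at this place, para to the 4-chlorophenyl group, neither the six-membered non-aromatic ring nor the drop from 9 heavy atoms to 4 moves the number beyond the scatter, even with the aromatic carbon now carrying the nitrogen of the acetamido group rather than a carbonyl carbon. No supporting data are available to account for this flat result.

On these data alone, all three compounds sit in the same narrow band, so it remains open whether any group at this place can shift the number, for example a free amine, a carboxylic acid or a longer chain on the acetamido carbonyl. As far as these compounds go, the 4-chlorophenyl group and the rest of the shared core are common to all three compounds, so their bearing on this read-out also remains open.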